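Swapping the Ester on Compound 2

The source may report more compounds than this note shows. Statements on the series, on what has been measured and on what is new or still open speak of the compounds shown alone.

compound 1 `CC(=O)O[C@H]1CC[C@]2(C)[C@H](CC[C@@](C)(O)[C@H]2CC[C@@H]2C(C)=CC[C@H]3[C@H](CC[C@]3(C)OC(C)=O)C2(C)C)OC1(C)C` gives 26200 nM
compound 2 `CC(=O)O[C@H]1CC[C@]2(C)[C@H](CC[C@@](C)(O)[C@H]2CC[C@@H]2C(C)=CC[C@@H]3C(C)=CC[C@@H]3C2(C)C)OC1(C)C` gives 39200 nM

In a functional assay on MDA-MB-231 cells (Homo sapiens) for antiproliferative activity, read by MTT assay, with a stated time of 72 h (a lower number here means a stronger inhibitor, a higher number a weaker inhibitor), compound 2 stands at 39200 nM and compound 1 at 26200 nM and these two numbers lie within the scatter of each other. Compound 3 `CC1=CC[C@H]2[C@@H]1CC=C(C)[C@@H](CC[C@H]1[C@]3(C)CC[C@H](OC(=O)c4ccc(C)cc4)C(C)(C)O[C@H]3CC[C@@]1(C)O)C2(C)C` has 4-methylphenyl in place of methyl on a carbonyl carbon. For the measured compounds named here, no measured step shows the effect of this change. A modest shift toward a lower number in this assay is therefore expected, with the estimate being a 2.6-fold lower number from compound 2 to compound 3 (0.42 log units; beyond the scatter) and its uncertainty wide. Compound 3 is estimated at 15000 nM (range 5000 nM to 40000 nM).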

Compound 3, half-maximal inhibitory concentration: 32700 nM
The estimate for compound 3 lay 2.2-fold (0.34 log units) below the measured number; measured number inside the range.
By their numbers in this assay, from the lowest: compounds 1, 3 and 2 (each within the scatter of the next).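

In this assay the step of a 1.2-fold lower number from compound 2 to compound 3 (0.08 log units; within the scatter) shows that this position accepts 4-methylphenyl, with its seven heavy atoms and six-membered aromatic ring, in place of methyl on a carbonyl carbon without leaving the scatter. For the compounds shown here, the earlier compounds held no change at this place, so this is the first reading of it. Nothing measured here explains this result. Going by these compounds, what an amine or a longer chain would give on this carbonyl carbon remains open. So does whether a free hydroxyl could replace the whole ester.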